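Carbamate in place of urea on the aminothiazole amide

The source may hold more compounds than are shown below. What is called first, only, known or untested is meant among the compounds shown, and "the series" means these compounds.

Measured compounds:
- compound 1 `CC(=O)c1cccc(Nc2nc(-c3sc(NC(=O)NCc4ccc(Cl)cc4)nc3C)cs2)c1`: "not determined" (no result reported)
- compound 2 `CC(=O)c1cccc(Nc2nc(-c3sc(NC(=O)C(C)(C)C)nc3C)cs2)c1`: 8830 nM
- compound 3 `CC(=O)c1cccc(Nc2nc(-c3sc(NC(=O)c4ccc(I)cc4)nc3C)cs2)c1`: "not determined" (no result reported)

Compound 1 carries a urea on the exocyclic nitrogen of the shared core, and in an ADME assay on RD cells (Homo sapiens) for cytotoxicity, read by microscopy (on this read-out higher numbers stand for lower toxicity in this test and lower numbers for higher toxicity in this test), compound 1 has no single number to stand on; the same is true of compound 3, which has an iodobenzoyl amide in that place and for which compound 3 gives "not determined" (no result reported). Going by the values given here, the only number in this assay belongs to compound 2, where compound 2 gives 8830 nM.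

Compound 4 `CC(=O)c1cccc(Nc2nc(-c3sc(NC(=O)OC(C)(C)C)nc3C)cs2)c1` arises from compound 1 by the change (tert-butoxy in place of (4-chlorobenzyl)amino on a carbonyl carbon). Among the compounds with values here, no pair of measured compounds shares this change, so the step cannot be sized from the data. Compound 4 does, however, resemble compound 2 closely: both place a small branched group on the carbonyl carbon, a tert-butoxy in compound 4 and a tert-butyl in compound 2. On that resemblance, and on the value of compound 2 alone, compound 4 is expected in this assay to lie near 8000 nM, within a range from 3000 nM to 25000 nM.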

Compound 4, half-maximal cytotoxic concentration: 101000 nM
Estimate against measurement, compound 4: 13-fold (1.10 log units) below; measured number above the stated range.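

In this assay, tert-butoxy in place of tert-butyl on a carbonyl carbon gives an 11-fold higher number from compound 2 to compound 4 (1.06 log units; beyond the scatter) with the rest of the molecule unchanged. Going by these compounds alone, this is the first step that can be read at this position, and it shows that two small branched groups on this carbonyl carbon need not read alike: the number is higher with tert-butoxy, which in this test stands for lower toxicity. The step from compound 1 to compound 4 cannot be read, as compound 1 gives "not determined" (no result reported) and so offers no number to set against compound 4.

Nothing at hand accounts for the size of this step. From the compounds shown here alone, whether a methoxy, a benzyloxy or a tert-butylamino group on the same carbonyl carbon would read like compound 4 or like compound 2 stays open.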